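Moving the chlorine and nitrogen on the pyridinyl group

The source may hold more compounds than are shown below. What is called first, only, known or untested is meant among the compounds shown, and "the series" means these compounds.

Measured in an ADME assay on cells (Hepatocyte, Rattus norvegicus, strain Wistar) for pharmacokinetics, read by LC-MS, with a stated time of 90 min, tested at 1 uM; on this read-out lower numbers stand for slow clearance and higher numbers for fast clearance:
Compound 1 `COc1cc(C(=O)N2CC[C@@H](O)C(C)(C)C2)cc2nc(NCc3cccc(Cl)c3)oc12`: 51.7 mL/min/kg
Compound 2 `COc1cc(C(=O)N2CCC(O)C(C)C2)cc2nc(NCc3cccc(Cl)c3)oc12`: 45 mL/min/kg
Compound 3 `COc1cc(C(=O)N2CCC(O)C(C)C2)cc2nc(NCc3cc(Cl)ccn3)oc12`: 14.3 mL/min/kg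

Compound 3 has the lowest number of the three, and both others lie beyond the scatter above it. Compound 4 `COc1cc(C(=O)N2CCC(O)C(C)C2)cc2nc(NCc3cncc(Cl)c3)oc12` differs from it in one group: 5-chloropyridin-3-yl in place of 4-chloropyridin-2-yl on a saturated chain carbon bound to a nitrogen on an aromatic ring. Here 5-chloropyridin-3-yl takes the place of 4-chloropyridin-2-yl on a saturated chain carbon bound to a nitrogen on an aromatic ring.

The most relevant measured step is a 3.1-fold lower number from compound 2 to compound 3 (0.50 log units; beyond the scatter), a change at this same place in which 4-chloropyridin-2-yl replaced 3-chlorophenyl. The step of a 1.1-fold lower number from compound 1 to compound 2 (0.06 log units; within the scatter) concerns the group on the carbonyl carbon and bears little on this change. Among the measured compounds shown here, no measured compound carries 5-chloropyridin-3-yl, so the data cannot show whether the lower number of compound 3 carries over. A small upward shift in this assay, not beyond the scatter, is therefore expected. The expected change is a 1.4-fold higher number from compound 3 to compound 4 (0.15 log units; within the scatter). For compound 4 the estimate is 20 mL/min/kg, with an expected range of 10 mL/min/kg to 38 mL/min/kg.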

Compound 4, clearance: 40 mL/min/kg
For compound 4 the middle estimate is 2.0-fold (0.30 log units) below the measured one; measured number above the stated range.
By their numbers in this assay, from the lowest: compound 3; then compounds 4, 2 and 1 (each within the scatter of the next).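

In this assay, rearranging the same atoms gave a 2.8-fold higher number from compound 3 to compound 4 (0.45 log units; beyond the scatter), so the pyridinyl group at this place does not by itself go with the lower number. The step of a 1.1-fold lower number from compound 2 to compound 4 (0.05 log units; within the scatter), set against that, puts 5-chloropyridin-3-yl level with 3-chlorophenyl, and among the three groups compared on this scaffold only 4-chloropyridin-2-yl stands apart. Nothing available here explains why the two pyridinyl groups differ.

As far as these compounds go, it remains open whether a fluorine in place of the chlorine on 4-chloropyridin-2-yl would keep the lower number, and whether a methyl or a methoxy in that place would do so. Also open, from the compounds shown here alone, is whether 4-chloropyridin-2-yl would have the same effect alongside the 4-hydroxy-3,3-dimethylpiperidin-1-yl of compound 1.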